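The compounds below may be only part of what the source reports. "The series", "measured", "known", "first", "only" and "open" are said of these compounds alone.

Working notes on the series. The shared core carries a nitro group and a sulfur-linked benzyl arm that varies; compound 1 is `O=C(O)c1ccc(C(=O)/C(=C\c2ccc(F)c([N+](=O)[O-])c2)SCc2ccc(Cl)cc2)cc1`, compound 2 is `O=C(O)c1ccc(C(=O)/C(=C\c2ccc(F)c([N+](=O)[O-])c2)SCc2ccc(C(F)(F)F)cc2)cc1`, compound 3 is `O=C(O)c1ccc(C(=O)/C(=C\c2ccc(F)c([N+](=O)[O-])c2)SCc2ccc(Cl)cc2Cl)cc1`. In a physicochemical assay for solubility (a lower number here means a less soluble compound, a higher number a more soluble compound), compound 1 gives < 1000 ug/mL, which is a limit of the assay. In this assay compound 2 gives < 1000 ug/mL, also a limit. In this assay compound 3 gives < 1000 ug/mL, again a limit. The measured steps a step that the two limits leave unreadable from compound 1 to compound 2, a step that the two limits leave unreadable from compound 1 to compound 3 and a step that the two limits leave unreadable from compound 2 to compound 3 are therefore all unreadable in size, since every value sits at the limit of < 1000 ug/mL in this assay, at which 3 of the 3 values shown sit. Compound 4 is `O=C(O)c1ccc(C(=O)/C(=C\c2ccc(F)c([N+](=O)[O-])c2)SCc2ccccc2Cl)cc1`; the change from compound 3 is hydrogen in place of chloro on an aromatic carbon. Within the data shown here, no measured step shows how a change of this kind reads in this assay. For compound 4 a step that the limit leaves unreadable from compound 3 to compound 4 is expected, with no direction claimed. Compound 4 is estimated at 500 ug/mL, between 100 ug/mL and 1500 ug/mL, and a further limit is likely because the limit of < 1000 ug/mL in this assay, at which 3 of the 3 values shown sit, holds every value seen so far.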

Compound 4, solubility: < 1000 ug/mL
Compound 4: only a limit was reported; the forecaster's own chance of this, stated with the estimate: 80%; the middle value is on the limit's open side.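

In this assay, among these compounds, compound 4 gives < 1000 ug/mL, a limit, so no step from compound 1, compound 2 or compound 3 to compound 4 can be read. Whether any change in the benzyl arm shifts the read-out in this assay stays open, with every value shown a limit: the limit of < 1000 ug/mL in this assay, at which 4 of the 4 values shown sit.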